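A few compounds are considered here, and "the series" means these few. Any claim that something is new, unique, unknown or untested is made for them only; others in the source may bear on it.

Three long-chain amides have been tested in a functional assay on PANC-1 cells (Homo sapiens) for cytotoxicity, read by WST assay, with a stated time of 24 h (on this read-out lower numbers stand for stronger inhibition and higher numbers for weaker inhibition), and none of them gave a number. Compound 1 (`O=C(/C=C/CCCCCCc1ccccc1)N[C@H]1CC[C@H](O)CC1`) reads > 100000 nM, which is a limit of the assay and not a measured value. Compound 2 (`O=C(/C=C/CCCCCCc1ccccc1)N1CCC(O)CC1`) reads > 100000 nM, again a limit. On these data alone, compound 3 (`O=C(CCCCCCCCCc1ccccc1)N1CCCCC1`) reads > 100000 nM, also a limit, so its true standing is unknown.

Compound 4 (`COc1ccc(CCCCCCCCC(=O)N2CCCCC2)cc1`) has not yet been measured. Its difference from compound 3 is 4-methoxyphenyl in place of benzyl on a saturated chain carbon, eight bonds along the chain from a carbonyl carbon. In words, this is 4-methoxyphenyl in place of benzyl on a saturated chain carbon, eight bonds along the chain from a carbonyl carbon.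

Going by the values given here, the only measured step is a step that the two limits leave unreadable from compound 1 to compound 2. It concerns a different change, 4-hydroxypiperidin-1-yl in place of (4-hydroxycyclohexyl)amino on a carbonyl carbon, and it has no readable size. Among the compounds with values here, no measured step therefore speaks directly to this change. What remains is the overall picture: the limit of > 100000 nM in this assay, at which 3 of the 3 values shown sit. On that basis, no readable step in either direction is expected in this assay, and the most likely report is the same limit. The estimated change is a number no higher from compound 3 to compound 4 (the limit leaves the size open). For compound 4, the estimated value is 100000 nM, with an expected range from 40000 nM to 200000 nM.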

Compound 4, half-maximal inhibitory concentration: 89300 nM
Estimate against measurement, compound 4: 1.1-fold (0.05 log units) above, and the stated range covers the measured number.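

In this assay, going by these compounds alone, compound 4 gives 89300 nM, the first value that is a real number, with 4-methoxyphenyl in place of benzyl on a saturated chain carbon, eight bonds along the chain from a carbonyl carbon. For compound 3 the reading > 100000 nM is a limit and not a number, and it is the common reading in this small set: the limit of > 100000 nM in this assay, at which 3 of the 4 values shown sit. On these data alone, the change therefore amounts to an at least 1.1-fold lower number from compound 3 to compound 4 (0.04 log units; that floor lies within the scatter), so this position can carry a change that brings the reading inside the measurable range, but the true size of the step stays unknown, and it may be as small as the scatter or much larger.

The compounds shown leave open whether the methoxy group itself matters or whether another group on the ring, such as 4-hydroxyphenyl or 4-chlorophenyl at the same place, would give a similar or a lower number. They also leave open whether 4-methoxyphenyl would bring a measurable number on the unsaturated chain of compound 1 and compound 2, whose hydroxyl-bearing amides cannot yet be read.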